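This account rests on a few compounds, and the source may have more. Where it says the series, first, only, none or still open, it means among the compounds named here.

compound 1 `CCN1CCN(c2cc(C)c3cc(NC(=O)c4ccccc4F)ccc3n2)CC1`: 38100 nM
compound 2 `CCN1CCN(c2cc(C)c3cc(NC(=O)c4ccccc4C)ccc3n2)CC1`: 29200 nM
compound 3 `CCN1CCN(c2cc(C)c3cc(NC(=O)c4ccc(Cl)cc4)ccc3n2)CC1`: 3020 nM

In a functional assay on SK-BR-3 cells (Homo sapiens) for antiproliferative activity, read by MTT assay, with a stated time of 72 h (a lower number here means a stronger inhibitor, a higher number a weaker inhibitor), compound 1 stands at the highest of the three numbers; compound 2 sits a 1.3-fold lower number from compound 1 to compound 2 (0.12 log units; within the scatter), so the two are not told apart, while compound 3 sits a 13-fold lower number from compound 1 to compound 3 (1.10 log units; beyond the scatter). Compound 4 `CCN1CCN(c2cc(C)c3cc(NC(=O)c4cc(Cl)cc(Cl)c4)ccc3n2)CC1` differs from compound 1 by 3,5-dichlorophenyl in place of 2-fluorophenyl on a carbonyl carbon. Within the data shown here, no measured step brings in a 3,5-dichlorophenyl, so the closest guides are the steps that bring in a chloro-bearing phenyl: a 13-fold lower number from compound 1 to compound 3 (1.10 log units; beyond the scatter) and a 9.7-fold lower number from compound 2 to compound 3 (0.99 log units; beyond the scatter), both beyond the scatter and both lowering the number. A step of comparable size, downward, is therefore expected for compound 4, an 8.5-fold lower number from compound 1 to compound 4 (0.93 log units; beyond the scatter). Compound 4 is estimated at 4500 nM, with a range from 1200 nM to 15000 nM.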

Compound 4, half-maximal inhibitory concentration: 2660 nM
Compound 4: the middle estimate sits 1.7-fold (0.23 log units) above what was measured, within the range that was stated.
By their numbers in this assay, from the lowest: compounds 4 and 3 (each within the scatter of the next); then compounds 2 and 1 (each within the scatter of the next).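

In this assay, 3,5-dichlorophenyl on the carbonyl carbon also gives a step beyond the scatter from each of the two compounds with a 2-substituted phenyl (a 14-fold lower number from compound 1 to compound 4 (1.16 log units; beyond the scatter); an 11-fold lower number from compound 2 to compound 4 (1.04 log units; beyond the scatter)). Set against 4-chlorophenyl, the dichloro group is not told apart (a 1.1-fold lower number from compound 3 to compound 4 (0.06 log units; within the scatter)), so the second chlorine adds no measurable change here. No measured evidence bears on this result.

Open, from the compounds shown here alone, is whether chlorine or its placement sets these numbers, which 2-chlorophenyl on the same carbonyl carbon would separate. Also open, going by these compounds, is whether 4-methoxyphenyl or 3,5-dimethylphenyl would match the chlorinated compounds.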